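Replacing bromo with ethoxycarbonyl in compound 1

A few compounds are considered here, and "the series" means these few. Any claim that something is new, unique, unknown or untested is made for them only; others in the source may bear on it.

Compound 1 `CCOCCOC(=O)C(=O)Nc1nc(-c2cc(Br)no2)cs1`: 11 mg/kg
Compound 2 `CCOCCOC(=O)C(=O)Nc1nc(-c2cc(Br)no2)c(CC)s1`: 3 mg/kg

Both compounds were tested in a functional assay on the whole organism with Rattus norvegicus as the target; on this read-out lower numbers stand for an effect already at smaller amounts and higher numbers for an effect only at larger amounts of compound. Among the measured compounds shown here, compound 1 holds the higher of the two numbers, and the only measured step is a 3.7-fold lower number from compound 1 to compound 2 (0.56 log units; beyond the scatter), with ethyl in place of hydrogen on an aromatic carbon. Compound 3 `CCOCCOC(=O)C(=O)Nc1nc(-c2cc(C(=O)OCC)no2)cs1` awaits measurement in this assay. It differs from compound 1 at another place, with ethoxycarbonyl in place of bromo on an aromatic carbon, next to the ring nitrogen: ethoxycarbonyl in place of bromo on an aromatic carbon. For the measured compounds named here, no measured step replaces the bromo, so the ethyl step gives neither a size nor a direction for this change. The data therefore support no expected shift beyond the scatter. The expected change is a 1.1-fold lower number from compound 1 to compound 3 (0.04 log units; within the scatter). For compound 3 the estimate is 10 mg/kg, with an expected range of 3.5 mg/kg to 30 mg/kg.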

Compound 3, dose for half-maximal effect: 0.08 mg/kg
The estimate for compound 3 lay 130-fold (2.10 log units) above the measured number; the measured number lies below the stated range.
By their numbers in this assay, from the lowest: compound 3; then compound 2; then compound 1.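

In this assay the step of a 140-fold lower number from compound 1 to compound 3 (2.14 log units; beyond the scatter) comes with ethoxycarbonyl in place of bromo, which shows that the aromatic carbon next to the ring nitrogen, untouched by the earlier comparison, is a place where one change can shift the number strongly downward. The step of a 3.7-fold lower number from compound 1 to compound 2 (0.56 log units; beyond the scatter) at the other place is the smaller of the two, so the larger effect seen so far belongs to this position. No measurement here shows what lies behind the shift, or which part of the ethoxycarbonyl group carries it.

Open, from the compounds shown here alone, is whether the shift is particular to ethoxycarbonyl, or whether a carboxylic acid, a primary amide or a longer alkyl ester at this carbon would do the same. Also open, going by these compounds, is whether ethyl at the other place and ethoxycarbonyl at this one would add up in a single compound.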